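The source may report more compounds than this note shows. Statements on the series, on what has been measured and on what is new or still open speak of the compounds shown alone.

The measured compounds in a functional assay on DU-145 cells (Homo sapiens) for inhibition, read by trypan blue exclusion, with a stated time of 96 h (a higher number here means a weaker inhibitor of growth, a lower number a stronger inhibitor of growth), are these:
Compound 1, `O=C(/C(=C\c1ccc(Br)c(O)c1)S(=O)(=O)c1ccc(Br)cc1)c1ccc(Br)cc1`, gives 50000 nM.
Compound 2, `Cc1ccc(/C=C(/Sc2ccc(F)cc2)C(=O)c2ccc(Cl)cc2)s1`, gives 25000 nM.
Compound 3, `O=C(/C(=C\c1ccc(O)c([N+](=O)[O-])c1)SCc1ccc(Br)cc1)C1CCNC1`, gives > 100000 nM, which is a limit of the assay and not a number.

Of the two compounds that return a number in this assay, compound 1 holds the higher one, yet its gap to compound 2 lies within the usual scatter of repeated measurements, so the two cannot be set apart. The value of compound 3 sits at the limit of > 100000 nM in this assay, at which 1 of the 3 values shown sits, so it adds no number to compare.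

The compound still to be measured is compound 4, `O=C(/C(=C\c1ccc(Br)c([N+](=O)[O-])c1)S(=O)(=O)c1ccc(Br)cc1)c1ccc(Br)cc1`. Set against compound 1 it differs in one place: nitro in place of hydroxy on an aromatic carbon. Among the measured compounds shown here, no measured pair in this set differs by that change alone, so there is no step on record to lean on; the three measured compounds differ from one another in several places at once and share no single change with this one.

With nothing in the measured set pointing one way, the step from compound 1 to compound 4 in this assay, a 1.2-fold higher number from compound 1 to compound 4 (0.08 log units; within the scatter), is expected to be small, with no clear direction beyond the scatter. The estimate for compound 4 is 60000 nM, within a range of 20000 nM to 200000 nM, and it is expected that the assay may return only a limit for compound 4.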

Compound 4, concentration for 50% growth inhibition: 10000 nM
Estimate against measurement, compound 4: 6.0-fold (0.78 log units) above; the whole stated range lies above it.
By their numbers in this assay, from the lowest: compound 4; then compounds 2 and 1 (each within the scatter of the next). At a limit, above all of these: compound 3.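

In this assay, among the compounds shown here, replacing the 4-bromo-3-hydroxyphenyl of compound 1 with the 4-bromo-3-nitrophenyl of compound 4 gives the first step in this set that isolates a single change, with a 5.0-fold lower number from compound 1 to compound 4 (0.70 log units; beyond the scatter). It shows that the group on this aromatic carbon, ortho to a bromo group and meta to a large group, can alter the read-out, although the step is modest. It also shows that the hydroxy, with its hydrogen-bond donor, is not required at this position for growth inhibition on the core of compound 1, and that the larger nitro is tolerated there. Nothing measured here bears on why the step occurs.

The compounds shown leave open whether the step reflects the arrival of the nitro or only the departure of the hydroxy, a question that an amine, a methoxy or a nitrile on the same carbon would help to settle. They also leave open whether the same exchange would give a step of similar size and direction on a different core.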